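This account rests on a few compounds, and the source may have more. Where it says the series, first, only, none or still open, it means among the compounds named here.

Measured in a functional assay on A549 cells (Homo sapiens) for antiproliferative activity, read by MTT assay, with a stated time of 48 h; a lower number here means a stronger inhibitor, a higher number a weaker inhibitor:
- Compound 1 `COc1ccc(C(=O)c2ccc(OC)c3c2OC(C)(C)C=C3)c(NC(=O)CBr)c1`: 1210 nM
- Compound 2 `COc1ccc(C(=O)c2ccc3c(c2)C=CC(C)(C)O3)c(NC(=O)CBr)c1`: 1980 nM
- Compound 3 `COc1ccc(C(=O)c2ccc(OC)c3c2OC(C)(C)C=C3)c(NC(=O)CO)c1`: 80 nM

In this assay compound 3 gives the lowest of the three numbers, 80 nM, while compound 2 lies furthest from it at 1980 nM. Compound 4 `COc1ccc(C(=O)c2ccc(OC)c3c2OC(C)(C)C=C3)c(NC(=O)CN)c1` has amino in place of hydroxy on a saturated chain carbon bound to a carbonyl carbon. Among the measured compounds shown here, one measured step bears on this place: a 15-fold lower number from compound 1 to compound 3 (1.18 log units; beyond the scatter), a large change with hydroxy in place of bromo. For the measured compounds named here, that step shows the place matters, but no measured compound carries amino there, so its size does not carry over. The expected result is a 1.6-fold higher number from compound 3 to compound 4 (0.21 log units; within the scatter), with no clear change beyond the scatter. For compound 4 the estimate is 130 nM, with an expected range of 35 nM to 500 nM.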

Compound 4, half-maximal inhibitory concentration: 270 nM
Beside the measured number, compound 4's estimate is 2.1-fold (0.32 log units) below it; low and high end bracket the measured number.
By their numbers in this assay, from the lowest: compound 3; then compound 4; then compounds 1 and 2 (each within the scatter of the next).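

In this assay, the step of a 3.4-fold higher number from compound 3 to compound 4 (0.53 log units; beyond the scatter) shows that hydroxy and amino are not interchangeable on this saturated chain carbon bound to a carbonyl carbon, although both count the same hydrogen-bond donors and acceptors. Amino still improves on bromo, with a 4.5-fold lower number from compound 1 to compound 4 (0.65 log units; beyond the scatter), so on this core the number rises from hydroxy to amino to bromo. Nothing measured here explains this order. As far as these compounds go, how a carboxylic acid or a longer chain would fare at this place remains open. So does whether the same order holds on the core of compound 2.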